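The source may report more compounds than this note shows. Statements on the series, on what has been measured and on what is new or still open speak of the compounds shown alone.

Compound 2 (`CC(C(=O)NOCc1ccccc1)N1C(=O)S/C(=C\c2ccc(C(F)(F)F)cc2)C1=O`) is tested in an ADME assay on RAW264.7 cells (Mus musculus) for cytotoxicity, read by neutral red uptake, with a stated time of 24 h (on this read-out higher numbers stand for lower toxicity in this test and lower numbers for higher toxicity in this test), alongside two close relatives. In this assay compound 2 gives > 128000 nM as its result, which is a limit of the assay and not a number. Compound 1 (`O=C(CN1C(=O)S/C(=C\c2ccc(C(F)(F)F)cc2)C1=O)NOCc1ccccc1`) gives > 128000 nM as its result, also a limit. Compound 3 (`C=CCONC(=O)C(C)N1C(=O)S/C(=C\c2ccc(C(F)(F)F)cc2)C1=O`) gives > 128000 nM as its result, again a limit. So compound 2 stands level with everything measured so far, which amounts to the limit of > 128000 nM in this assay, at which 3 of the 3 values shown sit, and gives no ranking among the three.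

Compound 4 (`CCCC/C=C1\SC(=O)N(C(C)C(=O)NOCc2ccccc2)C1=O`) keeps the rest of compound 2 but carries butyl in place of 4-(trifluoromethyl)phenyl on a double-bonded chain carbon bound to a double-bonded ring carbon. Two measured steps involve compound 2. Methyl in place of hydrogen gave a step that the two limits leave unreadable from compound 1 to compound 2 as its outcome, and vinyl in place of phenyl gave a step that the two limits leave unreadable from compound 2 to compound 3 as its outcome. Neither has a readable size, and neither alters the group that changes here, so they offer only weak guidance. The expectation therefore rests on compound 2 and its limit (> 128000 nM).

In this assay the estimated change is a number no higher from compound 2 to compound 4 (the limit leaves the size open), so no step beyond the scatter is expected. For compound 4 the expected value is 128000 nM, with an estimated range from 50000 nM to 256000 nM.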

Compound 4, half-maximal cytotoxic concentration: 43900 nM
Compound 4: the middle estimate sits 2.9-fold (0.46 log units) above what was measured; the whole stated range lies above it.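

In this assay, butyl in place of 4-(trifluoromethyl)phenyl gives an at least 2.9-fold lower number from compound 2 to compound 4 (0.46 log units; beyond the scatter), so this place on the double-bonded chain carbon is the only one shown where a change has a readable effect, and it points towards higher toxicity in this test. The two earlier steps, at other places in the molecule, cannot be read, and so they could not show whether any part of these compounds affects the result. The size of the new step is only a minimum, and the true gap may be larger, as the values shown still sit mostly at one ceiling: the limit of > 128000 nM in this assay, at which 3 of the 4 values shown sit.

On these data alone, what stays open is which part of the swap matters, since the aromatic ring, the fluorine atoms and the chain length all change at once, and a plain phenyl ring or a longer chain such as hexyl at this place would help to pull these apart. As far as these compounds go, it is also open whether butyl would lower the number to a similar extent on the shared core of compound 1 or compound 3.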